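This account rests on a few compounds, and the source may have more. Where it says the series, first, only, none or still open, it means among the compounds named here.

Compound 1 `Cc1ccncc1-c1ccc2[nH]c(=O)nc(-c3ccccc3)c2c1` stands at the edge of what an ADME assay on THP-1 cells (Homo sapiens) for cytotoxicity, read by MTT assay, with a stated time of 72 h (on this read-out lower numbers stand for an effect already at smaller amounts and higher numbers for an effect only at larger amounts of compound), can report. In this assay compound 1 gives > 50000 nM, which is a limit of the assay and not a number. Compound 2 `CN(C)c1ccc(-c2ccc3[nH]c(=O)nc(-c4ccccc4)c3c2)cn1` also sits at a limit; in this assay compound 2 gives > 50000 nM. Both values sit at the same limit (the limit of > 50000 nM in this assay, at which 2 of the 2 values shown sit), so compound 1 cannot be ordered against compound 2. Compound 3 `O=c1nc(-c2ccccc2)c2cc(-c3cccc(F)c3)ccc2[nH]1` is to be measured in this assay. It differs from compound 1 by 3-fluorophenyl in place of 4-methylpyridin-3-yl on an aromatic carbon. Within the data shown here, no step between measured compounds is available. Because both measured values sit at the limit (the limit of > 50000 nM in this assay, at which 2 of the 2 values shown sit), the expected step that the limit leaves unreadable from compound 1 to compound 3 is none beyond the scatter. Compound 3 is estimated at 60000 nM, within 25000 nM to 150000 nM.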

Compound 3, half-maximal effective concentration: > 50000 nM
Compound 3 was reported as a limit; the forecaster's own chance of this, stated with the estimate: 80%; the middle value does not contradict the limit.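

In this assay no new step can be read from compound 1 to compound 3, because both values are limits and not numbers: the limit of > 50000 nM in this assay, at which 3 of the 3 values shown sit 

On these data alone, whether any group at this place on the shared core gives a value short of that limit stays open.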